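The source may report more compounds than this note shows. Statements on the series, on what has been measured and on what is new or still open speak of the compounds shown alone.

Measured compounds:
compound 1, `Nc1nccn2cc(-c3ccco3)nc12` — 5%
compound 2, `Nc1nc(Br)cn2cc(-c3ccccc3)nc12` — 14%
compound 3, `COc1ccc(-c2cn3cc(Br)nc(N)c3n2)cc1` — 24%

In an assay on cells for displacement of a labelled ligand from transmembrane domain-containing protein TMIGD3 (Homo sapiens), read by scintillation counting, with a stated time of 120 min, tested at 1 uM (a lower number here means less inhibition, a higher number more inhibition at the concentration tested (going by the name of the read-out)), compound 2 gives 14%. Among the three numbers it stands second highest: its nearest neighbour is compound 1, whose 5% lies within the scatter of it, and its furthest is compound 3, whose 24% also lies within the scatter. Among the measured compounds shown here, the single measured step, a number 10 percentage points higher from compound 2 to compound 3 (within the scatter), therefore shows no change that can be told from repeat measurements.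

Compound 4, `COc1cccc(-c2cn3cc(-c4ccccc4)nc3c(N)n2)c1`, differs from compound 2 in one place: 3-methoxyphenyl in place of bromo on an aromatic carbon. For the measured compounds named here, no measured step exchanges bromo for an aryl group, so nothing in this set speaks directly to the change. Going by the values given here, the one step that exists, a number 10 percentage points higher from compound 2 to compound 3 (within the scatter), concerns a methoxy on the pendant phenyl and bears on compound 4 only in that it, too, carries a methoxyphenyl; that step stayed within the scatter.

On this footing the account expects for compound 4 a step of a number 6 percentage points higher from compound 2 to compound 4 (within the scatter), small and of uncertain direction. Compound 4 is estimated to give 20% in this assay, with a range from 5% to 40%.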

Compound 4, a percentage reported as inhibition, at one concentration (the size of the read-out at that concentration, not a potency): 21%
The estimate for compound 4 lay 1 percentage points below the measured number, and the stated range covers the measured number.
By their numbers in this assay, from the lowest: compounds 1, 2, 4 and 3 (each within the scatter of the next, the first and the last beyond it).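

In this assay, the exchange of bromo for 3-methoxyphenyl on the aromatic carbon next to the ring nitrogen amounts to a number 7 percentage points higher from compound 2 to compound 4 (within the scatter). Among the compounds shown here, this is the first measured change at this position of the shared core, as the earlier step concerned a methoxy on the pendant phenyl, and it shows that a single bromine can give way to a group of 8 heavy atoms with its own six-membered aromatic ring without a change that can be told from repeat measurements. No evidence at hand bears on why the number stays within the scatter.

The compounds shown leave open whether an unsubstituted phenyl, a 4-methoxyphenyl, an amine, a carboxylic acid or a longer chain in place of bromo on this carbon would move the number beyond the scatter. They also leave open how compound 2 and compound 4 would compare as a full concentration series, since each number here is the size of the read-out at one concentration and not a potency.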